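Swapping Methyl for Hydroxy on the Shared Core

The source may report more compounds than this note shows. Statements on the series, on what has been measured and on what is new or still open speak of the compounds shown alone.

Measured so far in a functional assay, with a stated time of 30 min, tested at 20 uM; on this read-out higher numbers stand for more inhibition at the one concentration tested (going by the name of the read-out) and lower numbers for less inhibition:
Compound 1, `Cc1ccc(-c2nnc(Nc3ncccn3)o2)cc1`, gives < 20%, which is a limit of the assay rather than a number.
Compound 2, `COc1ccc(-c2nnc(Nc3ncccn3)o2)cc1OC`, gives 49.5%.
Compound 3, `COc1cc(-c2nnc(Nc3ncccn3)o2)cc(OC)c1OC`, gives 57.7%.

Compound 1 thus stands at the limit of < 20% in this assay, at which 1 of the 3 values shown sits, with no number of its own. Compounds 2 and 3, which carry methoxy groups, give real numbers in this assay. Compound 4, `Oc1ccc(-c2nnc(Nc3ncccn3)o2)cc1`, differs from compound 1 by hydroxy in place of methyl on an aromatic carbon. Within the data shown here, the only measured step, a number 8.2 percentage points higher from compound 2 to compound 3 (within the scatter), concerns a methoxy group rather than a hydroxy group, so it bears on this change only loosely. Since compounds 2 and 3 show that oxygen substituents go with measurable numbers, a modest rise is expected for compound 4, namely a number at least 8 percentage points higher from compound 1 to compound 4 (that floor lies within the scatter). Compound 4 is therefore estimated at 28%, within a range from 5% to 55%.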

Compound 4, a percentage reported as inhibition, at one concentration (the size of the read-out at that concentration, not a potency): 63.4%
Compound 4: middle estimate off by 35.4 percentage points, on the low side; measured number above the stated range.
By their numbers in this assay, from the lowest: compounds 2, 3 and 4 (each within the scatter of the next, the first and the last beyond it). At a limit, below all of these: compound 1.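

In this assay, putting hydroxy in place of methyl on an aromatic carbon, para to a large group, gives a number at least 43.4 percentage points higher from compound 1 to compound 4 (beyond the scatter) with this one change. A lone hydroxy at this place is thus enough to bring the shared core from a limit to a real number, with no methoxy group present. Compound 1 has only a limit and no number of its own, so the size of this step is a floor: the limit of < 20% in this assay, at which 1 of the 4 values shown sits.

From the compounds shown here alone, whether hydroxy is special here stays open: an amine, a carboxylic acid or a fluorine at the same place could settle that. The compounds shown also leave open what hydroxy would give on another carbon of that ring.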